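Swapping Cyclopentyl for Methylphenyl on the Amine

The source may report more compounds than this note shows. Statements on the series, on what has been measured and on what is new or still open speak of the compounds shown alone.

Measured compounds:
compound 1, `O=C1C(Nc2ccc(Br)cc2)=CC(=O)c2c1nc1n2[C@H]2OC[C@@H](O)[C@H]2OC1`, gives 4330 nM in a functional assay on MCF7 cells (Homo sapiens) for inhibition, read by sulforhodamine B assay; on this read-out lower numbers stand for stronger inhibition and higher numbers for weaker inhibition
compound 2, `CCc1ccc(NC2=CC(=O)c3c(nc4n3[C@H]3OC[C@@H](O)[C@H]3OC4)C2=O)cc1`, gives 8990 nM in this assay
compound 3, `O=C1C=C(NC2CCCC2)C(=O)c2c1nc1n2[C@H]2OC[C@@H](O)[C@H]2OC1`, gives > 16000 nM in this assay

For compound 3 the result is only a limit of the assay, not a number (the limit of > 16000 nM in this assay, at which 1 of the 3 values shown sits). Among the three compounds shown, compound 3 is thus the one without a measured value.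

Compound 4, `Cc1ccc(NC2=CC(=O)c3nc4n(c3C2=O)[C@H]2OC[C@@H](O)[C@H]2OC4)cc1`, has not yet been measured. It differs from compound 3 by 4-methylphenyl in place of cyclopentyl on an amine nitrogen.

Going by the values given here, the only measured step, a 2.1-fold higher number from compound 1 to compound 2 (0.32 log units; beyond the scatter), changes a substituent on an aromatic ring and does not touch the cyclopentyl-to-aromatic exchange, so no measured step bears directly on this change. Compounds 1 and 2 both carry an aromatic group on the same amine nitrogen and both give numbers rather than limits, so compound 4 is expected to give a number as well. Compound 4 is estimated at 7000 nM, with a range from 3000 nM to 16000 nM, which would mean a step of an at least 2.2-fold lower number from compound 3 to compound 4 (0.35 log units; beyond the scatter).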

Compound 4, half-maximal inhibitory concentration: 1660 nM
Beside the measured number, compound 4's estimate is 4.2-fold (0.62 log units) above it; measured number outside the range, below it.
By their numbers in this assay, from the lowest: compound 4; then compound 1; then compound 2. At a limit, above all of these: compound 3.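

In this assay, 4-methylphenyl in place of cyclopentyl on the amine nitrogen gives an at least 9.6-fold lower number from compound 3 to compound 4 (0.98 log units; beyond the scatter), the only step shown that replaces the whole group on this nitrogen rather than a substituent on an aromatic ring. With this core, the group on the amine nitrogen can therefore decide whether a measurable number appears at all. The figure for compound 3 is a limit of the assay and not a number, so the step gives only a minimum size: the limit of > 16000 nM in this assay, at which 1 of the 4 values shown sits.

The compounds shown cannot tell whether the aromatic ring or its methyl matters more, since plain phenyl and cyclohexyl on the same nitrogen would be needed to separate the two. On these data alone, compounds 1 and 2 differ from compound 4 in more than one place, so how bromo or ethyl would behave on compound 4 also stays open.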